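Swapping a chlorophenyl for a styryl group on the core

A few compounds are considered here, and "the series" means these few. Any claim that something is new, unique, unknown or untested is made for them only; others in the source may bear on it.

Measured so far:
compound 1, `Cc1cc(O)c(C2=NN(c3ccc(S(N)(=O)=O)cc3)C(c3ccccc3O)C2)cc1Cl`: 11300 nM
compound 2, `Cc1cc(O)c(C2=NN(c3ccc(S(N)(=O)=O)cc3)C(c3ccccc3Cl)C2)cc1Cl`: 6770 nM

In a functional assay on OVCAR-3 cells (Homo sapiens) for antiproliferative activity, with a stated time of 48 h (a lower number here means that less compound is tolerated, a higher number that more compound is tolerated), compound 1 gives 11300 nM, while compound 2 gives 6770 nM. Within the data shown here, the only step measured, a 1.7-fold lower number from compound 1 to compound 2 (0.22 log units; within the scatter), concerns a hydroxy-to-chloro exchange on an aromatic carbon and stays within the scatter. Compound 2 therefore stands at the lowest of the two numbers, with compound 1 as its nearest neighbour, but the two cannot be told apart.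

Compound 3, `Cc1cc(O)c(C2=NN(c3ccc(S(N)(=O)=O)cc3)C(/C=C/c3ccccc3)C2)cc1Cl`, has not yet been measured. It differs from compound 2 by 2-phenylethenyl in place of 2-chlorophenyl on a saturated ring carbon, in short 2-phenylethenyl in place of 2-chlorophenyl on a saturated ring carbon. Among the measured compounds shown here, no measured step bears on this kind of change at this position; the single step available changes a different ring and is small. A step from compound 2 to compound 3 of a 1.0-fold lower number from compound 2 to compound 3 (0.02 log units; within the scatter) is therefore expected, with no direction beyond the scatter. Compound 3 is estimated at 6500 nM, with a range from 2000 nM to 20000 nM.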

Compound 3, concentration lethal to 50% of the cells: 70200 nM
Compound 3: the middle estimate sits 11-fold (1.03 log units) below what was measured, outside the stated range (above it).
By their numbers in this assay, from the lowest: compounds 2 and 1 (each within the scatter of the next); then compound 3.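

The group on the saturated ring carbon clearly matters in this assay: 2-phenylethenyl in place of 2-chlorophenyl gives a 10-fold higher number from compound 2 to compound 3 (1.02 log units; beyond the scatter) and in place of 2-hydroxyphenyl gives a 6.2-fold higher number from compound 1 to compound 3 (0.79 log units; beyond the scatter), so in both comparisons more compound is tolerated with the new group. The earlier exchange of hydroxy for chloro on the aromatic ring of this group stayed within the scatter, so it gave no sign that replacing the whole group could shift the number this far. Nothing available explains the shift.

The compounds shown leave open whether the double bond itself or the longer link to the phenyl ring goes with the higher number. A 2-phenylethyl group or an unsubstituted phenyl group at this carbon would help separate the two.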